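The source may hold more compounds than are shown below. What is called first, only, known or untested is meant among the compounds shown, and "the series" means these compounds.

Going by the values given here, in a functional assay on CHO cells for agonist activity at Free fatty acid receptor 1 (Homo sapiens), read by FLIPR and calcium flux, tested at 1 uM (a higher number here means that more compound is needed for the effect, a lower number that less compound is needed), compound 2 `Cc1ccc(OCc2nnc(C(=O)Nc3ccc(CCC(=O)O)cc3)s2)c(C)c1` gives 2540 nM, the lowest of the two numbers so far; compound 1 `O=C(O)CCc1ccc(NC(=O)c2nnc(COc3ccc(F)cc3)s2)cc1` gives 5390 nM. Among the compounds with values here, the only measured step, a 2.1-fold lower number from compound 1 to compound 2 (0.33 log units; beyond the scatter), came with 2,4-dimethylphenyl replacing 4-fluorophenyl on the same oxygen. Compound 3 `Cc1cccc(OCc2nnc(C(=O)Nc3ccc(CCC(=O)O)cc3)s2)c1` carries 3-methylphenyl in place of 2,4-dimethylphenyl on an oxygen on a saturated carbon. Within the data shown here, that single step is the only one bearing on this exchange and it does not cover it directly, so the expectation is a step of a 1.4-fold higher number from compound 2 to compound 3 (0.14 log units; within the scatter), a slight rise in the number or none beyond the scatter. Compound 3 is estimated at 3500 nM, with a range from 1800 nM to 7000 nM.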

Compound 3, half-maximal effective concentration: 3260 nM
The estimate for compound 3 lay 1.1-fold (0.03 log units) above the measured number; the range from low to high includes it.
By their numbers in this assay, from the lowest: compounds 2, 3 and 1 (each within the scatter of the next, the first and the last beyond it).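

In this assay, 3-methylphenyl in place of 2,4-dimethylphenyl gives a 1.3-fold higher number from compound 2 to compound 3 (0.11 log units; within the scatter). In place of 4-fluorophenyl, the same group gives a 1.7-fold lower number from compound 1 to compound 3 (0.22 log units; within the scatter). Going by these compounds alone, compound 3 therefore cannot be separated from either compound 1 or compound 2 on this aryl group on the oxygen, and only the pair of compound 1 and compound 2 stands beyond the scatter, so these three aryl groups span a narrow range of numbers.

From the compounds shown here alone, whether a methoxy group, an amine or a longer chain on this phenyl ring would move the number beyond the scatter remains open. Nothing available here explains the numbers for these aryl groups.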